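This account rests on a few compounds, and the source may have more. Where it says the series, first, only, none or still open, it means among the compounds named here.

Measured compounds:
compound 1 `CN1CCC[C@H]1COc1cccc(C#CCCCCO)c1` gives 4400 nM
compound 2 `CN1CCC[C@H]1COc1cc(O)cc(-c2ccccc2)c1` gives 528 nM
compound 3 `CN1CCC[C@H]1COc1cc(O)cc(-c2ccc(O)cc2)c1` gives 3.8 nM

All three numbers come from an assay on membranes from Cerebral cortex for displacement of a labelled ligand from Neuronal acetylcholine receptor; alpha4/beta2 (Rattus norvegicus), with a stated time of 30 min; a higher number here means a weaker inhibitor, a lower number a stronger inhibitor. Compound 1 stands at the top of the three, with the weakest binding; the nearest number is that of compound 2, which is clearly lower, and the furthest is that of compound 3, which is lower by a wide margin. Among the compounds with values here, the only single-point step among the measured compounds is the one from compound 2 to compound 3, a 140-fold lower number from compound 2 to compound 3 (2.14 log units; beyond the scatter), a hydroxy added on an aromatic carbon of the distal ring of the biphenyl-type compound.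

Compound 4 `CN1CCC[C@H]1COc1cc(C#CCCCCO)cc([N+](=O)[O-])c1` differs from compound 1 by nitro in place of hydrogen on an aromatic carbon. Within the data shown here, no measured step shows a nitro entering, and the hydroxy step from compound 2 to compound 3 concerns a different group on a different ring, so it does not bear on this change. The shared core and the 6-hydroxyhex-1-yn-1-yl chain of compound 1 are kept. With nothing comparable measured, a step within the scatter is expected for compound 4, a 1.1-fold lower number from compound 1 to compound 4 (0.04 log units; within the scatter), in this assay, with a broad range to reflect the absent precedent. Compound 4 is therefore estimated at 4000 nM, between 1200 nM and 13000 nM.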

Compound 4, inhibition constant: 14.2 nM
Compound 4: middle estimate off by 280-fold (2.45 log units), on the high side, and the stated range ends above it.
By their numbers in this assay, from the lowest: compound 3; then compound 4; then compound 2; then compound 1.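

The position on the aromatic ring of compound 1 that is meta to a (1-methylpyrrolidin-2-yl)methoxy group and meta to a 6-hydroxyhex-1-yn-1-yl group is not a silent one: in this assay, nitro in place of hydrogen there gives a 310-fold lower number from compound 1 to compound 4 (2.49 log units; beyond the scatter) with the rest of the structure unchanged. Within the data shown here, until now the only single-place step was the hydroxy change, a 140-fold lower number from compound 2 to compound 3 (2.14 log units; beyond the scatter) on the series with an aromatic ring in place of the chain, so a second large step now stands, with a different group at a different place and with the 6-hydroxyhex-1-yn-1-yl group kept. Nothing at hand accounts for the size of the nitro step.

On these data alone, whether this step belongs to nitro itself or would also come with another group at the same position, such as an amine, a nitrile or a carboxylic acid, stays open. Also open, as far as these compounds go, is whether nitro gives a step of this size when the 6-hydroxyhex-1-yn-1-yl group gives way to a shorter chain or to a phenyl ring.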